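The source may hold more compounds than are shown below. What is called first, only, known or untested is meant among the compounds shown, and "the series" means these compounds.

Compound 1 `C=CCSc1nncc2c(CC)ncn12` — in a functional assay for inhibition, with Homo sapiens as the target (a lower number here means a stronger inhibitor, a higher number a weaker inhibitor), compound 1 gives > 48000 nM, a limit of the assay rather than a number.
Compound 2 `Cc1nc(Cc2ccccc2)n2c(O)nncc12` — in this assay compound 2 gives > 48000 nM, again a limit rather than a number.
Compound 3 `CCCc1nc(C)c2cnnc(O)n12` — in this assay compound 3 gives 56800 nM.

Compound 2 therefore stands at the limit of this assay, and it is not alone there: the limit of > 48000 nM in this assay, at which 2 of the 3 values shown sit, so only compound 3 yields an actual number. For the measured compounds named here, the one measured step that starts from compound 2, a step that the limit leaves unreadable from compound 2 to compound 3, swaps ethyl in place of phenyl on a saturated chain carbon bound to an aromatic carbon, and the limit hides how large that step is or which way it goes.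

Compound 4 `Oc1nncc2c(Br)nc(Cc3ccccc3)n12` differs from compound 2 by bromo in place of methyl on an aromatic carbon. Going by the values given here, no measured step touches this position, and the only measured step, at another place, is unreadable, so the expectation rests on where compound 2 itself stands. With the starting point already at the limit, compound 4 is expected to land in the same weak region, the estimated step that the limit leaves unreadable from compound 2 to compound 4 being none beyond the scatter. The estimate for compound 4 is 60000 nM, with a range from 20000 nM to 200000 nM, and a fair chance that only a limit is reported.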

Compound 4, half-maximal inhibitory concentration: > 48000 nM
Compound 4 was reported as a limit; the forecaster's own chance of this, stated with the estimate: 60%; the middle value lies beyond the limit too.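

For the compounds shown here, compound 4 and compound 2 are both reported only as limits, so replacing methyl with bromo on an aromatic carbon gives no step that can be read. How far either compound lies beyond that limit, and whether this replacement changes inhibition at all, stays open, with most of the results resting at one value: the limit of > 48000 nM in this assay, at which 3 of the 4 values shown sit.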